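The source may report more compounds than this note shows. Statements on the series, on what has been measured and on what is new or still open speak of the compounds shown alone.

Compound 1, `CC(C)=CCC/C(C)=C/CC/C(C)=C/CC[C@@H]1[C@@]2(C)CC/C(=N\OCc3cn(-c4ccc(F)c(Cl)c4)nn3)C(C)(C)[C@@H]2CC[C@@]1(C)O`, is a terpenoid oxime ether carrying a triazole with a 3-chloro-4-fluorophenyl group on an aromatic nitrogen. In a functional assay on DU-145 cells (Homo sapiens) for cytotoxicity, read by MTT assay, with a stated time of 48 h (a higher number here means a weaker inhibitor, a lower number a stronger inhibitor), compound 1 gives 26900 nM. Compound 2, `CC(C)=CCC/C(C)=C/CC/C(C)=C/CC[C@@H]1[C@@]2(C)CC/C(=N\OCc3cn(-c4c(Cl)cc([N+](=O)[O-])cc4Cl)nn3)C(C)(C)[C@@H]2CC[C@@]1(C)O`, differs from it by 2,6-dichloro-4-nitrophenyl in place of 3-chloro-4-fluorophenyl on an aromatic nitrogen. In this assay compound 2 gives 16400 nM, a step of a 1.6-fold lower number from compound 1 to compound 2 (0.21 log units; within the scatter). Compound 3, `CC(C)=CCC/C(C)=C/CC/C(C)=C/CC[C@@H]1[C@@]2(C)C/C(=C\c3ccc(OCc4cn(-c5ccc(F)c(Cl)c5)nn4)cc3)C(=O)C(C)(C)[C@@H]2CC[C@@]1(C)O`, is built on a different core; the difference between the two cores is not broken down here. In this assay compound 3 gives 28400 nM. Compound 4, `CC(C)=CCC/C(C)=C/CC/C(C)=C/CC[C@@H]1[C@@]2(C)C/C(=C\c3ccc(OCc4cn(-c5c(Cl)cc([N+](=O)[O-])cc5Cl)nn4)cc3)C(=O)C(C)(C)[C@@H]2CC[C@@]1(C)O`, has not yet been measured; it differs from compound 3 by 2,6-dichloro-4-nitrophenyl in place of 3-chloro-4-fluorophenyl on an aromatic nitrogen, the same change as that from compound 1 to compound 2. For compound 4 a step of a 1.5-fold lower number from compound 3 to compound 4 (0.17 log units; within the scatter) is expected, because the earlier step was a 1.6-fold lower number from compound 1 to compound 2 (0.21 log units; within the scatter). Compound 4 is therefore estimated at 19000 nM, with a likely range of 9000 nM to 40000 nM.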

Compound 4, half-maximal inhibitory concentration: 20900 nM
The estimate for compound 4 lay 1.1-fold (0.04 log units) below the measured number, within the range that was stated.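

In this assay, replacing 3-chloro-4-fluorophenyl with 2,6-dichloro-4-nitrophenyl gives a 1.4-fold lower number from compound 3 to compound 4 (0.13 log units; within the scatter), and the step on this core agrees with the step on the other: the same change on two cores in this assay, a 1.6-fold lower number (0.21 log units; within the scatter) from compound 1 to compound 2 and a 1.4-fold lower number (0.13 log units; within the scatter) from compound 3 to compound 4, 1.2-fold (0.08 log units) apart, within the scatter of two such steps. Both steps lie within the scatter, so this is agreement between two small steps, and it does not show that the change has a real effect on either core. Two cores are also too few to show that the change would carry over in the same way to any other core in the series.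

On these data alone, it remains open whether a different group on the aromatic nitrogen, such as an unsubstituted phenyl, a benzyl or a chain ending in an amine, would move the number beyond the scatter on either core. As far as these compounds go, it also remains open whether the two steps would still agree with such a group in place.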